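Swapping an Aryl Group for Cyclopropyl on a Triazole

The source may hold more compounds than are shown below. What is called first, only, known or untested is meant among the compounds shown, and "the series" means these compounds.

Of the compounds shown here, three built on one shared core have been tested in an ADME assay on PC-3 cells (Homo sapiens) for cytotoxicity, read by sulforhodamine B assay, with a stated time of 48 h, tested at 10 uM; on this read-out higher numbers stand for more inhibition at the one concentration tested (going by the name of the read-out) and lower numbers for less inhibition. Compound 1 `COc1nc2ccc(Br)cc2cc1C(c1ccccc1)n1cc(-c2ccc(Br)cc2)nn1` gives 7.43%. Compound 2 `CCCCc1cn(C(c2ccccc2)c2cc3cc(Br)ccc3nc2OC)nn1`, which carries butyl in place of 4-bromophenyl, gives 5.54%, and the step of a number 1.9 percentage points lower from compound 1 to compound 2 (within the scatter) is too small to mean anything. Compound 3 `COc1nc2ccc(Br)cc2cc1C(c1ccccc1)n1cc(-c2ccc(OC(F)(F)F)cc2)nn1` gives 21.6%, the highest of the three numbers: the step of a number 14.2 percentage points higher from compound 1 to compound 3 (beyond the scatter) and the step of a number 16.1 percentage points higher from compound 2 to compound 3 (beyond the scatter) both lie beyond the usual scatter, so compound 3 stands clearly above the other two.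

Compound 4 `COc1nc2ccc(Br)cc2cc1C(c1ccccc1)n1cc(C2CC2)nn1` has not yet been measured. It differs from compound 3 in one place: cyclopropyl in place of 4-(trifluoromethoxy)phenyl on an aromatic carbon. Going by the values given here, the step that bears most directly on this change is the one from compound 2 to compound 3, in which a small alkyl group gave way to the 4-(trifluoromethoxy)phenyl group and the number rose modestly. Compound 4 goes the other way, back to a small carbon ring on the same carbon, so a modest fall is expected, roughly undoing that rise, as a number 14.6 percentage points lower from compound 3 to compound 4 (beyond the scatter). Compound 4 is therefore estimated at 7%, with a likely range from 0% to 18%.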

Compound 4, a percentage reported as inhibition, at one concentration (the size of the read-out at that concentration, not a potency): 22.6%
The estimate for compound 4 lay 15.6 percentage points below the measured number; measured number outside the range, above it.
By their numbers in this assay, from the lowest: compounds 2 and 1 (each within the scatter of the next); then compounds 3 and 4 (each within the scatter of the next).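

The a number 1 percentage points higher from compound 3 to compound 4 (within the scatter) shows that on this aromatic carbon of the five-membered ring with 3 nitrogen, cyclopropyl, with 3 heavy atoms and one three-membered ring, does as well as 4-(trifluoromethoxy)phenyl, with 11 heavy atoms and one six-membered aromatic ring. The other two steps, a number 17.1 percentage points higher from compound 2 to compound 4 (beyond the scatter) with cyclopropyl in place of butyl and a number 15.2 percentage points higher from compound 1 to compound 4 (beyond the scatter) with cyclopropyl in place of 4-bromophenyl, show that neither the count of heavy atoms nor the presence of an aromatic ring sorts these four compounds: 4-bromophenyl sits with butyl in the lower pair, while 4-(trifluoromethoxy)phenyl sits with cyclopropyl in the higher pair. Nothing measured here explains why these groups pair up in this way.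

From the compounds shown here alone, whether this result is special to cyclopropyl remains open, and a cyclobutyl ring, an isopropyl group or a short chain ending in an amine on the same carbon could test that. Going by these compounds, each number also comes from a single concentration, so how the compounds would compare across a range of concentrations is unknown.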